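Notes on the dimethylamino step from compound 1

The source may report more compounds than this note shows. Statements on the series, on what has been measured and on what is new or still open speak of the compounds shown alone.

Compound 1 `O=C1/C(=C/c2ccccc2)CCc2ccccc21` carries the shared core of this set. In a functional assay on CCRF-CEM cells (Homo sapiens) for inhibition (on this read-out lower numbers stand for stronger inhibition and higher numbers for weaker inhibition), compound 1 gives 7420 nM, and compound 2 `O=C1/C(=C/c2cccc(F)c2)CCc2ccccc21` with 8010 nM and compound 3 `Cc1cccc(/C=C2\CCc3ccccc3C2=O)c1` with 9410 nM both give numbers within the scatter of that value. The steps measured so far are a 1.1-fold higher number from compound 1 to compound 2 (0.03 log units; within the scatter), a 1.3-fold higher number from compound 1 to compound 3 (0.10 log units; within the scatter) and a 1.2-fold higher number from compound 2 to compound 3 (0.07 log units; within the scatter); none of them moves this assay beyond the scatter. Compound 4 `CN(C)c1ccc(/C=C2\CCc3ccccc3C2=O)cc1` differs from compound 1 by dimethylamino in place of hydrogen on an aromatic carbon. Within the data shown here, no measured step introduces a dimethylamino group, or any group para to a large group, so the fluoro and methyl steps bear only loosely on this change; what they do show is that small substituents on this ring leave this assay essentially where compound 1 stands. The expected step is therefore a 1.2-fold lower number from compound 1 to compound 4 (0.09 log units; within the scatter), within the scatter or close to it. Compound 4 is estimated at 6000 nM in this assay, with a range from 2000 nM to 20000 nM that allows for an untested group at an untested place.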

Compound 4, half-maximal inhibitory concentration: 1650 nM
Compound 4: middle estimate off by 3.6-fold (0.56 log units), on the high side; the measured number lies below the stated range.
By their numbers in this assay, from the lowest: compound 4; then compounds 1, 2 and 3 (each within the scatter of the next).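

Dimethylamino in place of hydrogen, on an aromatic carbon para to a large group, is the only change shown that moves this assay beyond the scatter, with a 4.5-fold lower number from compound 1 to compound 4 (0.65 log units; beyond the scatter). The fluoro and methyl steps from compound 1 stay within the scatter, so compounds 2 and 3 go against any general reading that substitution on this ring lowers the number, while compound 4 shows that at least one substitution on it does. Nothing available bears on the cause of this step.

The compounds shown leave open whether the place or the group carries this step. A methoxy group, a primary amine or a diethylamino group at that same place, and dimethylamino elsewhere on the ring, would each bear on that question.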